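Ring Size at the Ester and a Thiophene Swap

The compounds below may be only part of what the source reports. "The series", "measured", "known", "first", "only" and "open" are said of these compounds alone.

Measured so far:
Compound 1, `CC1=C(C(=O)OCC2CC2)C(c2ccoc2)NC(=O)N1`, gives 3% in an assay on membranes from HeLa cells for displacement of a labelled ligand from adenosine receptor A3 (Homo sapiens), read by scintillation counting, with a stated time of 180 min, tested at 1 uM; a lower number here means less inhibition, a higher number more inhibition at the concentration tested (going by the name of the read-out).
Compound 2, `CC1=C(C(=O)OCC2CCC2)C(c2ccoc2)NC(=O)N1`, gives 2% in this assay.
Compound 3, `CC1=C(C(=O)OCC2CC2)C(c2ccsc2)NC(=O)N1`, gives 3% in this assay.

All three measured compounds share a six-membered core carrying an ester and a methyl group, and all three show only slight displacement of the labelled ligand. Compound 1 and compound 2 differ in the ring attached to the ester: cyclobutyl in place of cyclopropyl on a saturated chain carbon bound to an oxygen next to a carbonyl group. The step of a number 1 percentage points lower from compound 1 to compound 2 (within the scatter) is small. Compound 1 and compound 3 differ in the aromatic ring on the core: thiophen-3-yl in place of furan-3-yl on a saturated ring carbon. The step of no change at the digits printed from compound 1 to compound 3 (within the scatter) is likewise within the scatter, so the three numbers cannot be ordered.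

Compound 4, `CC1=C(C(=O)OCC2CCC2)C(c2ccsc2)NC(=O)N1`, has not yet been measured. It is reached from compound 3 by the same change that turns compound 1 into compound 2: cyclobutyl in place of cyclopropyl on a saturated chain carbon bound to an oxygen next to a carbonyl group. The place of the change is described in the same words for both pairs, so this is the same change, made on a core that differs only by the thiophene for furan swap just described.

Because a number 1 percentage points lower from compound 1 to compound 2 (within the scatter) was within the scatter, and because no change at the digits printed from compound 1 to compound 3 (within the scatter) shows the two cores behaving alike, the expected step of no change at the digits printed from compound 3 to compound 4 (within the scatter) is also small. Compound 4 is therefore estimated at 3% in this assay, expected to fall between -5% and 11%.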

Compound 4, a percentage reported as inhibition, at one concentration (the size of the read-out at that concentration, not a potency): 2%
Estimate against measurement, compound 4: 1 percentage points above; measured number inside the range.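

In this assay, cyclobutyl in place of cyclopropyl gives a number 1 percentage points lower from compound 3 to compound 4 (within the scatter), and this step matches the one seen when the same change was made with furan-3-yl on the core: the same change on two cores in this assay, a number 1 percentage points lower (within the scatter) from compound 1 to compound 2 and a number 1 percentage points lower (within the scatter) from compound 3 to compound 4, 0 percentage points apart, within the scatter of two such steps

Thiophen-3-yl in place of furan-3-yl gives no change at the digits printed from compound 2 to compound 4 (within the scatter), and this swap reads the same whether the ester carries cyclopropyl or cyclobutyl: the same change on two cores in this assay, no change at the digits printed (within the scatter) from compound 1 to compound 3 and no change at the digits printed (within the scatter) from compound 2 to compound 4, 0 percentage points apart, within the scatter of two such steps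

Within these four compounds, then, each change has the same small outcome on both cores, but two steps inside the scatter can agree without either change having any real effect, and this does not show that a change with a clear effect would carry from one core to another.

The compounds shown leave open whether any other group can raise the inhibition well above these low numbers, for example a longer chain or an amine on the ester, or a phenyl ring in place of thiophen-3-yl on the core. They also leave open how these compounds would behave at other concentrations, as a single concentration shows the size of the read-out there and gives no potency.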